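Swapping the Ether Chain on a Shared Aminonaphthyridine-like Core

This account rests on a few compounds, and the source may have more. Where it says the series, first, only, none or still open, it means among the compounds named here.

Measured so far:
compound 1 `Nc1ccc2cccc(OC3CCCCC3)c2n1` gives 361 nM in an assay on cells with melanin-concentrating hormone receptor 1 (Homo sapiens) as the target, read by radioligand binding; a higher number here means a weaker inhibitor, a lower number a stronger inhibitor
compound 2 `COC(C)(C)CCOc1cccc2ccc(N)nc12` gives 132 nM in this assay

Compound 2 holds the lower of the two numbers in this assay, and its gap to compound 1 is beyond the usual scatter. Compound 3 `CC(C)=CCOc1cccc2ccc(N)nc12` has not yet been measured. It differs from compound 2 in one place: 2-methylprop-1-en-1-yl in place of 2-methoxy-2-methylpropyl on a saturated chain carbon bound to an oxygen on an aromatic ring. For the measured compounds named here, no step between measured compounds matches this change, so the expectation rests on compound 2 alone. A modest shift toward a weaker inhibitor is expected in this assay, perhaps not beyond the scatter, giving a 1.5-fold higher number from compound 2 to compound 3 (0.18 log units; within the scatter). Compound 3 is expected to give about 200 nM in this assay, within a range from 60 nM to 650 nM.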

Compound 3, half-maximal inhibitory concentration: > 2000 nM
Compound 3: a limit, no number; the forecaster's own chance of this, stated with the estimate: 5%; at least 10-fold (1.00 log units) between middle value and limit.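

The ether chain on this oxygen matters far more than compounds 1 and 2 alone suggested: in this assay, 2-methylprop-1-en-1-yl in place of 2-methoxy-2-methylpropyl gives an at least 15-fold higher number from compound 2 to compound 3 (1.18 log units; beyond the scatter). 3-Methylbut-2-en-1-yl in place of cyclohexyl gives an at least 5.5-fold higher number from compound 1 to compound 3 (0.74 log units; beyond the scatter), so both earlier chains stand well ahead of this one. Compound 3 gives a limit of the assay, not a number, so both steps are minimum sizes: the limit of > 2000 nM in this assay, at which 1 of the 3 values shown sits.

From the compounds shown here alone, what stays open is which feature of the 2-methoxy-2-methylpropyl chain counts: its methoxy oxygen, its saturation or its length. A 3-methylbutyl chain, or a chain ending in a hydroxyl or an amine, could help separate these.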